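The source may hold more compounds than are shown below. What is called first, only, known or untested is meant among the compounds shown, and "the series" means these compounds.

Measured in an assay on microsomes from liver for inhibition of 3-hydroxy-3-methylglutaryl-coenzyme A reductase (Rattus norvegicus); on this read-out lower numbers stand for stronger inhibition and higher numbers for weaker inhibition: compound 1 `CC(C)c1c(C(=O)NCC2CCCCC2)nn(-c2ccc(F)cc2)c1OC[C@@H](O)C[C@@H](O)CC(=O)O` gives 17 nM; compound 2 `CC(C)c1c(C(=O)NCc2cccc(F)c2F)nn(-c2ccc(F)cc2)c1OC[C@@H](O)C[C@@H](O)CC(=O)O` gives 2 nM; compound 3 `Cc1ccc(CN(C)C(=O)c2nn(-c3ccc(F)cc3)c(OC[C@@H](O)C[C@@H](O)CC(=O)O)c2C(C)C)cc1` gives 37 nM.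

Compound 3 shows the highest number of the three in this assay: a 2.2-fold higher number from compound 1 to compound 3 (0.34 log units; beyond the scatter) and a 19-fold higher number from compound 2 to compound 3 (1.27 log units; beyond the scatter) both run toward it, while an 8.5-fold lower number from compound 1 to compound 2 (0.93 log units; beyond the scatter) sets the span among the other two. Compound 4 `CC(C)c1c(C(=O)N2CCCC2c2ccccc2)nn(-c2ccc(F)cc2)c1OC[C@@H](O)C[C@@H](O)CC(=O)O` differs from compound 3 by 2-phenylpyrrolidin-1-yl in place of methyl(4-methylbenzyl)amino on a carbonyl carbon. Both groups bring one six-membered aromatic ring of carbon only and no hydrogen-bond donors or acceptors. For the measured compounds named here, only one measured step, a 2.2-fold higher number from compound 1 to compound 3 (0.34 log units; beyond the scatter), reaches a group of that kind, and it was modest; no step between two such groups has been measured. Compound 4 is therefore expected to stay close to compound 3, a 1.1-fold higher number from compound 3 to compound 4 (0.03 log units; within the scatter), within or near the scatter. Estimated value for compound 4 in this assay: 40 nM, range 12 nM to 130 nM.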

Compound 4, half-maximal inhibitory concentration: 14 nM
Compound 4: the middle estimate sits 2.9-fold (0.46 log units) above what was measured; measured number inside the range.
By their numbers in this assay, from the lowest: compound 2; then compounds 4 and 1 (each within the scatter of the next); then compound 3.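

In this assay, the carbonyl carbon distinguishes 2-phenylpyrrolidin-1-yl from methyl(4-methylbenzyl)amino (a 2.6-fold lower number from compound 3 to compound 4 (0.42 log units; beyond the scatter)), so two groups that each carry one six-membered aromatic ring and no hydrogen-bond donors or acceptors are not interchangeable here. The new group does not separate from (cyclohexylmethyl)amino (a 1.2-fold lower number from compound 1 to compound 4 (0.08 log units; within the scatter)), but it does not match (2,3-difluorobenzyl)amino (a 7.0-fold higher number from compound 2 to compound 4 (0.85 log units; beyond the scatter)). No measured evidence bears on the reason for these differences. Still open, as far as these compounds go, is how morpholin-4-yl or 2-phenylpiperidin-1-yl would read on the same carbonyl carbon.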